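The source may hold more compounds than are shown below. What is called first, only, known or untested is meant among the compounds shown, and "the series" means these compounds.

Measured compounds:
Compound 1, `CCCCCCCC(C)(C)C(=O)Nc1c(OC)cc(OC)cc1OC`, gives 180 nM.
Compound 2, `CCCCCCCCCCCCCC(=O)Nc1c(OC)cc(OC)cc1OC`, gives 190 nM.

Both numbers come from an assay on microsomes from intestine for inhibition of acyl-CoA:cholesterol acyltransferase (Oryctolagus cuniculus); on this read-out lower numbers stand for stronger inhibition and higher numbers for weaker inhibition. Compound 2 has the higher of the two numbers, but its gap to compound 1 lies within the scatter, so the two compounds cannot be told apart on this read-out. Both share the same core, shown beside each structure, and both carry an amide on a saturated chain; in compound 1 the chain carbon bound to the carbonyl carries two methyl groups, in compound 2 it carries hydrogen, and the read-out does not separate them.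

Compound 3, `CCCCCCCCCCCCC(CC)C(=O)Nc1c(OC)cc(OC)cc1OC`, is the next step from compound 2: ethyl in place of hydrogen on a saturated chain carbon bound to a carbonyl carbon and a saturated chain carbon. Compound 1 with its 180 nM shows that substitution on the saturated chain carbon bound to the carbonyl carbon sits at the same level as compound 2. The step of a 1.2-fold lower number from compound 2 to compound 3 (0.07 log units; within the scatter) is therefore expected to stay within the scatter, with no clear direction. For compound 3 the estimated value in this assay is 160 nM, with a range from 60 nM to 450 nM.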

Compound 3, half-maximal inhibitory concentration: 52 nM
The estimate for compound 3 lay 3.1-fold (0.49 log units) above the measured number; the whole stated range lies above it.
By their numbers in this assay, from the lowest: compound 3; then compounds 1 and 2 (each within the scatter of the next).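

In this assay, ethyl in place of hydrogen on a saturated chain carbon bound to a carbonyl carbon and a saturated chain carbon gives a 3.7-fold lower number from compound 2 to compound 3 (0.56 log units; beyond the scatter), which shows that this position responds to substitution on this read-out. Compound 1 also carries substitution on that carbon, but its chain differs from that of compound 2 as well, so it could not isolate a single change there. The step to compound 3 is the first among these compounds to do so, and it lies beyond the scatter. The data shown offer no explanation for this step.

As far as these compounds go, it remains open whether a single methyl, a propyl or a longer chain on this same carbon would match the ethyl of compound 3, and whether a hydroxyl or an amine could stand in that place. Also open, from the compounds shown here alone, is how the length of the main saturated chain would act with the ethyl in place, and whether a change on the shared core would add to this step.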